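This account rests on a few compounds, and the source may have more. Where it says the series, first, only, none or still open, it means among the compounds named here.

Compound 1 `C#CCOC(=O)CC1C(C(=O)OCC#C)=C(N)Oc2ccc(-c3cc(OC)cc(OC)c3)cc21`: 1500 nM
Compound 2 `CCOC(=O)CC1C(C(=O)OCC)=C(N)Oc2ccc(-c3cccc(F)c3)cc21`: 76400 nM
Compound 3 `C#CCOC(=O)CC1C(C(=O)OCC)=C(N)Oc2ccc(-c3cccc(N)c3)cc21`: 3400 nM

In a functional assay on HL-60 cells (Homo sapiens) for cytotoxicity, read by CellTiter-Blue, with a stated time of 48 h (a lower number here means a stronger inhibitor, a higher number a weaker inhibitor), compound 2 gives 76400 nM, the highest of the three numbers. Compound 3 stands nearest to it with 3400 nM, and compound 1 furthest with 1500 nM; both gaps lie beyond the scatter, so compound 2 is the weakest inhibitor of the three on these data.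

Compound 4 `CCOC(=O)CC1C(C(=O)OCC)=C(N)Oc2ccc(-c3ccc(N)cc3)cc21` has not yet been measured in this assay. It differs from compound 2 in one place: 4-aminophenyl in place of 3-fluorophenyl on an aromatic carbon

Among the measured compounds shown here, no measured pair shows exactly this change, so its size can only be judged from the whole set. Compound 3, which carries an aminophenyl group and gives 3400 nM, also differs from compound 2 at one of its esters, so its number cannot be assigned to the aminophenyl group alone. For the measured compounds named here, still, the only compound with an amino group on the pendant ring sits well under compound 2, and the writer expects the step of a 5.1-fold lower number from compound 2 to compound 4 (0.71 log units; beyond the scatter) to point toward a stronger inhibitor, beyond the scatter but short of the gap to compound 3. On that reasoning the writer estimates compound 4 at 15000 nM, within the range 3000 nM to 60000 nM.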

Compound 4, half-maximal inhibitory concentration: 22300 nM
Compound 4: the middle estimate sits 1.5-fold (0.17 log units) below what was measured; the measured number falls inside the stated range.
By their numbers in this assay, from the lowest: compound 1; then compound 3; then compound 4; then compound 2.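

In this assay, among the compounds shown here, the exchange of 3-fluorophenyl for 4-aminophenyl on the aromatic carbon of the shared core gives a 3.4-fold lower number from compound 2 to compound 4 (0.53 log units; beyond the scatter) and is the first step in this set that can be read at this position on its own, with both ethyl esters unchanged. It shows that the group carried here matters: the exchange alone moves the number beyond the scatter toward a stronger inhibitor, though only modestly, whereas compound 3 could not show this since it also differs from compound 2 at an ester. Nothing measured here bears on why the number moves.

The step changes both the substituent, fluorine for an amino group, and where it stands on the pendant ring, so the compounds shown leave open how much of the step belongs to each of these two changes. Also open, going by these compounds, is how a plain phenyl ring, a hydroxyl group or a carboxylic acid on that ring would compare with the amino group on the same diethyl ester core.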